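This account rests on a few compounds, and the source may have more. Where it says the series, first, only, none or still open, it means among the compounds named here.

Compound 1, `Nc1scc(CN2CCN(c3ccc(F)cc3Cl)CC2)c1C(=O)c1ccc(Cl)cc1`: -6.2%
Compound 2, `Nc1scc(CN2CCN(c3ccc(F)cc3F)CC2)c1C(=O)c1ccc(Cl)cc1`: -17%

In a functional assay on CHO cells with adenosine receptor A1 (Homo sapiens) as the target, read by cAMP accumulation and immunoassay, with a stated time of 6 min, tested at 0.1 uM (on this read-out lower numbers stand for a stronger effect and higher numbers for a weaker effect at the one concentration tested), compound 2 stands lowest of the two numbers measured. Among the measured compounds shown here, the one measured step, a number 10.8 percentage points lower from compound 1 to compound 2 (beyond the scatter), separates it from compound 1. Compound 3, `Nc1scc(CN2CCN(CCCc3ccc(Cl)cc3)CC2)c1C(=O)c1ccc(Cl)cc1`, differs from compound 2 by 3-(4-chlorophenyl)propyl in place of 2,4-difluorophenyl on an amine nitrogen in a ring. For the measured compounds named here, no measured step bears on this change: the only step known swaps one halogen for another on an aromatic carbon, whereas here the whole aryl group is replaced by a chain. With both measured numbers low, compound 3 is expected to give -8%, within -32% to 16%. The expected step is a number 9 percentage points higher from compound 2 to compound 3 (within the scatter), not beyond the scatter.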

Compound 3, a percentage reported as activity, at one concentration (the size of the read-out at that concentration, not a potency): -3%
For compound 3 the middle estimate is 5 percentage points below the measured one; measured number inside the range.
By their numbers in this assay, from the lowest: compound 2; then compounds 1 and 3 (each within the scatter of the next).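

In this assay, placing 3-(4-chlorophenyl)propyl on the amine nitrogen in a ring in place of 2,4-difluorophenyl gives a number 14 percentage points higher from compound 2 to compound 3 (beyond the scatter) and shows that this position can take a chain-linked aryl group with only a modest shift. In place of 2-chloro-4-fluorophenyl, the same group gives a number 3.2 percentage points higher from compound 1 to compound 3 (within the scatter) and stays within the scatter, so the size of the change depends on the group that leaves. No evidence available explains either step. As far as these compounds go, it remains open how a shorter link, such as benzyl or 2-phenylethyl, would read here, or a plain propyl chain without the chlorophenyl end.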